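Dropping the benzyloxy group on the way to compound 3

A few compounds are considered here, and "the series" means these few. Any claim that something is new, unique, unknown or untested is made for them only; others in the source may bear on it.

Measured compounds:
compound 1, `O=C(/C=C/c1ccc(OCc2ccccc2)cc1)c1ccccc1`: 52.3%
compound 2, `O=C(/C=C/c1ccc(F)cc1)c1ccc(OCc2ccccc2)cc1`: "not determined" (no result reported)

For the measured compounds named here, compound 2 stands without a number of its own, its result in a functional assay on HCT-116 cells (Homo sapiens) for antiproliferative activity, read by sulforhodamine B assay, with a stated time of 3 days, tested at 25 uM (a higher number here means a stronger effect of the compound at the concentration tested, a lower number a weaker effect), being given as "not determined" (no result reported); the only measured value is that of compound 1, which in this assay gives 52.3%. Compound 3, `O=C(/C=C/c1ccc(F)cc1)c1ccccc1`, differs from compound 2 by hydrogen in place of benzyloxy on an aromatic carbon. Going by the values given here, with no measured step to lean on, the change is expected to bring a step of modest size in this assay, its direction uncertain. Compound 3 is therefore estimated at 40%, within a range of 15% to 70%.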

Compound 3, a percentage reported as inhibition, at one concentration (the size of the read-out at that concentration, not a potency): 86.8%
Compound 3: middle estimate off by 46.8 percentage points, on the low side; the whole stated range lies below it.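

In this assay, fluoro in place of benzyloxy on an aromatic carbon gives a number 34.5 percentage points higher from compound 1 to compound 3 (beyond the scatter) and so shows that the read-out does not depend on benzyloxy at this carbon in these compounds. Compound 2 has no result, so the step that removes its benzyloxy group to give compound 3 cannot be read. Nothing given here accounts for the rise. The compounds shown leave open whether the gain belongs to fluoro itself or simply to the loss of benzyloxy. They also leave open how hydrogen, methoxy or an amine would fare at this carbon.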